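A few compounds are considered here, and "the series" means these few. Any claim that something is new, unique, unknown or untested is made for them only; others in the source may bear on it.

Measured compounds:
compound 1, `O=C(Nc1ccc(Oc2ccnc3[nH]ccc23)cc1)c1nccc(-c2cccc(Cl)c2)n1`, 10200 nM
compound 2, `Cc1ccc(-c2ccnc(C(=O)Nc3ccc(Oc4ccnc5[nH]ccc45)c(F)c3)n2)cc1`, 7170 nM
compound 3, `O=C(Nc1ccc(Oc2ccnc3[nH]ccc23)c(F)c1)c1nccc(-c2cccc(Cl)c2)n1`, 1580 nM

In a functional assay on MCF7 cells (Homo sapiens) for cytotoxicity, read by MTT assay, with a stated time of 72 h (on this read-out higher numbers stand for weaker inhibition and lower numbers for stronger inhibition), compound 3 stands lowest of the three numbers; compound 2 sits nearest and compound 1 furthest, both separations beyond the scatter. Two single-point steps lead into compound 3: a 6.5-fold lower number from compound 1 to compound 3 (0.81 log units; beyond the scatter) and a 4.5-fold lower number from compound 2 to compound 3 (0.66 log units; beyond the scatter). Compound 4, `O=C(Nc1ccc(Oc2ccnc3[nH]ccc23)c(F)c1)c1nccc(-c2ccc([N+](=O)[O-])cc2)n1`, carries 4-nitrophenyl in place of 3-chlorophenyl on an aromatic carbon. For the measured compounds named here, no measured pair isolates a nitro group, so the only step that bears on this change is a 4.5-fold lower number from compound 2 to compound 3 (0.66 log units; beyond the scatter), which shows that the one other aryl group measured on this carbon, the 4-methylphenyl of compound 2, gave a higher number than the 3-chlorophenyl of compound 3. On that single comparison the number for compound 4 is expected to move back upward, by about a 2.5-fold higher number from compound 3 to compound 4 (0.40 log units; beyond the scatter), with wide uncertainty since one step is thin ground. Compound 4 is estimated at 4000 nM, within the range 1200 nM to 13000 nM.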

Compound 4, half-maximal inhibitory concentration: "not active" (no number reported)
Nothing numeric was reported for compound 4; there is nothing to compare the estimate with.
By their numbers in this assay, from the lowest: compound 3; then compounds 2 and 1 (each within the scatter of the next).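

For the compounds shown here, compound 4 is reported as not active with no number, so no step from compound 3 to compound 4 can be read. No evidence bears on this result. The compounds shown leave open how far 4-nitrophenyl differs numerically from 3-chlorophenyl.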